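Amide in place of urea: compound 3 at one concentration

A few compounds are considered here, and "the series" means these few. Any claim that something is new, unique, unknown or untested is made for them only; others in the source may bear on it.

Of the compounds shown here, two have been measured in a functional assay on BT-549 cells (Homo sapiens) for inhibition, read by sulforhodamine B assay, with a stated time of 48 h, tested at 1 uM; on this read-out lower numbers stand for a stronger effect and higher numbers for a weaker effect at the one concentration tested. Compound 1 `COc1cc(Cl)cc(-c2nn(-c3cccc(NC(=O)Nc4ccc(Cl)c(Cl)c4)c3)cc2-c2ccncc2)c1` gives 92%. Compound 2 `COc1cc(Cl)cc(-c2nn(-c3cccc(NC(=O)Nc4cccc(C(F)(F)F)c4)c3)cc2-c2ccncc2)c1` gives 93%. Among the measured compounds shown here, the one step between them, a number 1 percentage points higher from compound 1 to compound 2 (within the scatter), came with 3-(trifluoromethyl)phenyl in place of 3,4-dichlorophenyl on an amide-type nitrogen and did not move the read-out beyond its scatter. Compound 2 therefore stands within the scatter of compound 1, and neither can be called stronger or weaker on this read-out.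

Compound 3 `COc1cc(Cl)cc(-c2nn(-c3cccc(NC(=O)c4cccc(C(F)(F)F)c4)c3)cc2-c2ccncc2)c1` differs from compound 2 as follows: 3-(trifluoromethyl)phenyl in place of (3-(trifluoromethyl)phenyl)amino on a carbonyl carbon. For the measured compounds named here, no measured step touches the carbonyl carbon or the amide-type nitrogen, so nothing in the data speaks directly to this change. Going by the values given here, the only information available is that both measured compounds sit close together in this assay, and the single step between them was small. Compound 3 is therefore expected to show about the same read-out, with a number 1 percentage points lower from compound 2 to compound 3 (within the scatter) as the estimated step. The estimate for compound 3 is 92%, expected to fall between 80% and 100%.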

Compound 3, a percentage reported as activity, at one concentration (the size of the read-out at that concentration, not a potency): 94%
Compound 3: the middle estimate sits 2 percentage points below what was measured; the range from low to high includes it.
By their numbers in this assay, from the lowest: compounds 1, 2 and 3 (each within the scatter of the next).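

In this assay, among the compounds shown here, the new result is the first reading on the link itself rather than on the aryl group beyond it: with 3-(trifluoromethyl)phenyl placed directly on the carbonyl carbon in place of (3-(trifluoromethyl)phenyl)amino, the piece gives a number 1 percentage points higher from compound 2 to compound 3 (within the scatter). This exchange takes away one nitrogen and its hydrogen-bond donor, so in this small set the read-out at the one concentration tested does not depend on the urea form of the link. The wider exchange, with 3-(trifluoromethyl)phenyl in place of (3,4-dichlorophenyl)amino on the same carbonyl carbon, gives a number 2 percentage points higher from compound 1 to compound 3 (within the scatter), and no measurement at hand offers an explanation for how little these changes register.

Since all three compounds stay together within the scatter, the set does not show whether any change at this carbonyl carbon can shift the read-out at all, for instance a straight butyl chain, a morpholine amine or a phenyl ring carrying a carboxylic acid. It also leaves open whether the same exchange of link would remain as silent on a different shared core.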